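Two Aryl Piperazines and a Third Awaiting Its Value

The source may report more compounds than this note shows. Statements on the series, on what has been measured and on what is new or still open speak of the compounds shown alone.

Compound 1 `Nc1scc(CN2CCN(c3ccncc3)CC2)c1C(=O)c1ccc(Cl)cc1` and compound 2 `Nc1scc(CN2CCN(c3c(F)cccc3F)CC2)c1C(=O)c1ccc(Cl)cc1` share one core. In a functional assay on CHO cells with adenosine receptor A1 (Homo sapiens) as the target, read by cAMP accumulation and immunoassay, with a stated time of 6 min, tested at 1 uM (a lower number here means a stronger effect, a higher number a weaker effect of the compound at the concentration tested), compound 1 gives -8.3% and compound 2 gives -65%, so compound 2 stands lowest of the two, with a step of a number 56.7 percentage points lower from compound 1 to compound 2 (beyond the scatter). Compound 3 `Nc1scc(CN2CCN(c3cc(Cl)ccc3Cl)CC2)c1C(=O)c1ccc(Cl)cc1` carries the change (2,5-dichlorophenyl in place of 2,6-difluorophenyl on an amine nitrogen in a ring). Among the measured compounds shown here, no measured step swaps one halogenated phenyl for another, and the step from compound 1 to compound 2 concerns a different exchange, so only a modest expectation can be drawn from it. Compound 3 is expected to give -55% in this assay, between -85% and -20%, an estimated step of a number 10 percentage points higher from compound 2 to compound 3 (within the scatter).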

Compound 3, a percentage reported as activity, at one concentration (the size of the read-out at that concentration, not a potency): -42%
For compound 3 the middle estimate is 13 percentage points below the measured one, within the range that was stated.
By their numbers in this assay, from the lowest: compound 2; then compound 3; then compound 1.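

In this assay, swapping one halogenated phenyl for another at this place is not neutral, with a number 23 percentage points higher from compound 2 to compound 3 (beyond the scatter), although the change alters the halogen and its ring positions together and the two effects cannot be separated. The 2,5-dichlorophenyl group also keeps a clear distance from pyridin-4-yl, with a number 33.7 percentage points lower from compound 1 to compound 3 (beyond the scatter). Nothing measured here explains either step. On these data alone, what remains open is how a plain phenyl or a methoxyphenyl group would read at this place, and whether a single chlorine would be enough.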